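The compounds below may be only part of what the source reports. "The series", "measured", "known", "first", "only" and "open" are said of these compounds alone.

Compound 1 `CC(C)=CCC/C(C)=C/COc1cc(=O)n(CCCO)c2c1CC(CC=C(C)C)C(C)(C)C2`: 18.4%
Compound 2 `CC(C)=CCC1Cc2c(OCCCOc3ccc([N+](=O)[O-])cc3)cc(=O)n(CCCO)c2CC1(C)C`: 0%

Of the compounds shown here, two sharing one core have been measured in a functional assay on PANC-1 cells (Homo sapiens) for inhibition, read by MTT assay, with a stated time of 24 h, tested at 10 uM; on this read-out higher numbers stand for more inhibition at the one concentration tested (going by the name of the read-out) and lower numbers for less inhibition. Compound 1 gives 18.4% and stands highest of the two numbers; its nearest neighbour is compound 2, which gives 0%, the step being a number 18.4 percentage points lower from compound 1 to compound 2 (beyond the scatter). That single step is the only one measured, and it exchanged a long unsaturated chain on the saturated carbon bound to the ring oxygen for a group carrying a substituted aromatic ring.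

Compound 3 `CC(C)=CCC1Cc2c(OC(=O)Nc3cccc(F)c3)cc(=O)n(CCCO)c2CC1(C)C` has not been measured. It differs from compound 1 by (3-fluorophenyl)carbamoyl in place of 3,7-dimethylocta-2,6-dien-1-yl on an oxygen on an aromatic ring. The change resembles the one already seen: the chain that leaves in (3-fluorophenyl)carbamoyl in place of 3,7-dimethylocta-2,6-dien-1-yl on an oxygen on an aromatic ring is removed in favour of a group carrying an aromatic ring with one hydrogen-bond donor and one acceptor. For the measured compounds named here, the only step that bears on it is a number 18.4 percentage points lower from compound 1 to compound 2 (beyond the scatter), which was modest but beyond the scatter and went downward. A step downward of similar size is therefore expected from compound 1 to compound 3, namely a number 13.4 percentage points lower from compound 1 to compound 3 (beyond the scatter). In this assay compound 3 is accordingly estimated to give about 5%, with a range from 0% to 20%.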

Compound 3, a percentage reported as inhibition, at one concentration (the size of the read-out at that concentration, not a potency): 0%
Compound 3: middle estimate off by 5 percentage points, on the high side; the measured number falls inside the stated range.
By their numbers in this assay, from the lowest: compounds 2 and 3 (each within the scatter of the next); then compound 1.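

In this assay the exchange of 3,7-dimethylocta-2,6-dien-1-yl for (3-fluorophenyl)carbamoyl on an oxygen on an aromatic ring gave a number 18.4 percentage points lower from compound 1 to compound 3 (beyond the scatter), so a second replacement at this oxygen, with a different link to its aromatic ring and with a hydrogen-bond donor, also ends lower than the chain of compound 1. Compound 2 gives 0% and compound 3 gives 0%, so among the compounds shown, only compound 1, the one that keeps the open unsaturated chain on this oxygen, gives a number above these two, and none of the three goes against that. Nothing at hand explains why the number falls with this exchange.

With only these three compounds, the loss cannot be assigned either to the departure of the 3,7-dimethylocta-2,6-dien-1-yl chain or to the arrival of an aromatic ring, and a carbamoyl bearing a plain hexyl chain, or a simple benzyl group on the same oxygen, would help to separate the two. Going by these compounds, it also remains open whether a longer unsaturated chain on this oxygen would give a number above that of compound 1.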